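Removing a Ring Fluorine from a Silyl-Capped Alkyne

This account rests on a few compounds, and the source may have more. Where it says the series, first, only, none or still open, it means among the compounds named here.

Compound 1, `C#Cc1cc(-c2nc3ccccc3s2)ccc1N`: 15 nM
Compound 2, `C[Si](C)(C)C#Cc1cc(-c2nc3ccc(F)cc3s2)ccc1N`: 400 nM
Compound 3, `C[Si](C)(C)C#Cc1cc(-c2nc3c(F)cccc3s2)ccc1N`: 230 nM

In a functional assay on MDA-MB-468 cells (Homo sapiens) for inhibition, with a stated time of 72 h (on this read-out higher numbers stand for weaker inhibition of growth and lower numbers for stronger inhibition of growth), compound 3 gives 230 nM, the second highest of the three numbers. Compound 2 with 400 nM sits within the scatter of compound 3, while compound 1 with 15 nM lies far lower, beyond the scatter. Compound 4, `C[Si](C)(C)C#Cc1cc(-c2nc3ccccc3s2)ccc1N`, differs from compound 3 by hydrogen in place of fluoro on an aromatic carbon. Among the measured compounds shown here, compound 4 keeps the silyl-capped alkyne shared by compounds 2 and 3, which compound 1 lacks, so no measured pair isolates this change. Compounds 2 and 3 carry fluorine in different places yet give similar numbers, so the fluorine alone may not account for the gap to compound 1. A modest move toward lower numbers is expected, a 1.5-fold lower number from compound 3 to compound 4 (0.19 log units; within the scatter), possibly within the scatter. Compound 4 is estimated at 150 nM, range 40 nM to 500 nM.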

Compound 4, concentration for 50% growth inhibition: 560 nM
The estimate for compound 4 lay 3.7-fold (0.57 log units) below the measured number, and the stated range ends below it.
By their numbers in this assay, from the lowest: compound 1; then compounds 3, 2 and 4 (each within the scatter of the next, the first and the last beyond it).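

In this assay hydrogen in place of fluoro gives a 2.4-fold higher number from compound 3 to compound 4 (0.39 log units; beyond the scatter) and so carries a modest cost at this aromatic carbon, whereas the same kind of swap gives a 1.4-fold higher number from compound 2 to compound 4 (0.15 log units; within the scatter) and stays within the scatter. The far larger step is a 37-fold higher number from compound 1 to compound 4 (1.57 log units; beyond the scatter) when a group of 4 heavy atoms replaces a hydrogen atom on the triple-bonded carbon, so most of the gap to compound 1 goes with the silyl cap, not the fluoro. Nothing shown here explains why either change has this effect.

Open, from the compounds shown here alone, is whether chloro or methoxy on this aromatic carbon would match fluoro, and whether a smaller cap on the alkyne, such as methyl, would keep the lower number.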